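This account rests on a few compounds, and the source may have more. Where it says the series, first, only, none or still open, it means among the compounds named here.

Measured so far in an ADME assay on L1210/0 cells (Mus musculus) for cytotoxicity, with a stated time of 48 h; a higher number here means a weaker inhibitor, a lower number a stronger inhibitor:
Compound 1, `CC(=O)OCCOCn1cnc2c(Cl)nc(I)nc21`: 8600 nM
Compound 2, `Nc1nc2c(nc(I)n2COCCO)c(=O)[nH]1`: 111000 nM
Compound 3, `CC(=O)OCCOCn1cnc2c(Cl)nc(N)nc21`: > 200000 nM, a limit of the assay rather than a number, namely the limit of > 200000 nM in this assay, at which 1 of the 3 values shown sits.

Compound 3 differs from compound 1 by amino in place of iodo on an aromatic carbon, and that change brings an at least 23-fold higher number from compound 1 to compound 3 (1.36 log units; beyond the scatter). Compound 2 and compound 1 differ in more than one place; the difference between the two cores is not broken down here. Compound 4, `Nc1nc2c(nc(N)n2COCCO)c(=O)[nH]1`, awaits measurement and differs from compound 2 by amino in place of iodo on an aromatic carbon. The surroundings are not identical: the earlier change sits on a six-membered aromatic ring with 2 nitrogen, the new one on a five-membered aromatic ring with 2 nitrogen, so it is the same kind of change, not the same. In this assay the step from compound 2 to compound 4 is expected to be a 2.7-fold higher number from compound 2 to compound 4 (0.43 log units; beyond the scatter), a weakening of similar size, resting on an at least 23-fold higher number from compound 1 to compound 3 (1.36 log units; beyond the scatter). Compound 2 already gives 111000 nM, so the number expected for compound 4 is a high one. Compound 4 is thus estimated at 300000 nM, between 80000 nM and 1500000 nM.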

Compound 4, half-maximal inhibitory concentration: > 200000 nM
Compound 4: a limit, no number (the forecaster's own chance of this, stated with the estimate: 60%); the middle value lies beyond the limit too.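

In this assay, putting amino in place of iodo on the core of compound 2 gives an at least 1.8-fold higher number from compound 2 to compound 4 (0.25 log units; that floor lies within the scatter). Compound 4 gives > 200000 nM, which is a limit of the assay and not a number. The result fits the step seen on the core of compound 1, but it does not show that the change carries over between cores with the same size: the same change on two cores in this assay, an at least 23-fold higher number (1.36 log units; beyond the scatter) from compound 1 to compound 3 and an at least 1.8-fold higher number (0.25 log units; that floor lies within the scatter) from compound 2 to compound 4; the limit leaves it open whether they differ

The compounds shown leave open how far the number rises on either core once amino replaces iodo. They also leave open what other groups at the same place, such as a bromo group or a methylamino group, would give on these two cores.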